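Oxime-ether aryl variation on the shared core: compound 4

The source may hold more compounds than are shown below. What is called first, only, known or untested is meant among the compounds shown, and "the series" means these compounds.

Measured compounds in a functional assay on SW-620 cells (Homo sapiens) for cytotoxicity, read by sulforhodamine B assay, with a stated time of 48 h; on this read-out higher numbers stand for weaker inhibition and lower numbers for stronger inhibition:
compound 1 `COc1ccc(C2=NO[C@]3(C2)C(=O)O[C@@H]2[C@H]3CC[C@H](C)[C@]3(O)C=CC(=O)[C@@]23C)cc1`, 41000 nM
compound 2 `COc1cc(C2=NO[C@]3(C2)C(=O)O[C@@H]2[C@H]3CC[C@H](C)[C@]3(O)C=CC(=O)[C@@]23C)ccc1O`, 88000 nM
compound 3 `C[C@H]1CC[C@@H]2[C@@H](OC(=O)[C@]23CC(c2ccccc2F)=NO3)[C@]2(C)C(=O)C=C[C@@]12O`, 11000 nM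

Compound 1 stands second highest of the three numbers in this assay. Its nearest neighbour is compound 2, a 2.1-fold higher number from compound 1 to compound 2 (0.33 log units; beyond the scatter); the furthest is compound 3, a 3.7-fold lower number from compound 1 to compound 3 (0.57 log units; beyond the scatter). Compound 3 also separates from compound 2, an 8.0-fold lower number from compound 2 to compound 3 (0.90 log units; beyond the scatter), so the aryl group on the carbon with a double bond to nitrogen moves the read-out by modest but real amounts across the three.

Compound 4 `Cc1ccccc1C1=NO[C@]2(C1)C(=O)O[C@@H]1[C@H]2CC[C@H](C)[C@]2(O)C=CC(=O)[C@@]12C` differs from compound 1 in one place: 2-methylphenyl in place of 4-methoxyphenyl on a carbon with a double bond to nitrogen.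

Going by the values given here, the only measured step that bears on this change is that from compound 1 to compound 3, where a 2-fluorophenyl also replaced the 4-methoxyphenyl and gave a 3.7-fold lower number from compound 1 to compound 3 (0.57 log units; beyond the scatter). Among the compounds with values here, the 2-methylphenyl of compound 4 is not the same group, and no step with a methyl on the ring exists here, so the expectation is a step in the same direction as compound 3 but of uncertain size, plausibly smaller. Compound 4 is therefore expected to give 20000 nM, with an estimated range of 8000 nM to 50000 nM. The expected step is a 2.1-fold lower number from compound 1 to compound 4 (0.31 log units; beyond the scatter).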

Compound 4, half-maximal inhibitory concentration: 5000 nM
Beside the measured number, compound 4's estimate is 4.0-fold (0.60 log units) above it, and the stated range ends above it.
By their numbers in this assay, from the lowest: compound 4; then compound 3; then compound 1; then compound 2.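

In this assay the 2-methylphenyl group on the carbon with a double bond to nitrogen gives the lowest number of the four compounds, both against 4-methoxyphenyl (an 8.2-fold lower number from compound 1 to compound 4 (0.91 log units; beyond the scatter)) and against 4-hydroxy-3-methoxyphenyl (an 18-fold lower number from compound 2 to compound 4 (1.25 log units; beyond the scatter)), so this position allows a larger drop than compound 3 had shown. The lower number seen with 2-fluorophenyl is also not the limit here, since methyl in place of fluoro on an aromatic carbon goes further (a 2.2-fold lower number from compound 3 to compound 4 (0.34 log units; beyond the scatter)), and both aryl groups with a single substituent at the 2-position now sit below the two oxygen-bearing aryl groups of compound 1 and compound 2. Nothing available on these compounds accounts for this order of groups.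

Open, going by these compounds, is whether the trend continues with a longer chain such as 2-ethylphenyl, or with an amine or a carboxylic acid on the same ring carbon, and whether a methyl elsewhere on the ring, as in 4-methylphenyl, would give a similar number. Also open, on these data alone, is whether the order holds on any other core, as all four compounds share the core of compound 1.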